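A few compounds are considered here, and "the series" means these few. Any claim that something is new, unique, unknown or untested is made for them only; others in the source may bear on it.

Measured compounds:
compound 1 `N/C(=N\NC(=S)N1CCCC1)c1ccccn1` with 24.7% in a functional assay on HeLa cells (Homo sapiens) for cytotoxicity, read by MTT assay, with a stated time of 72 h, tested at 1 uM; a lower number here means less inhibition of growth, a higher number more inhibition of growth at the concentration tested
compound 2 `Cc1ccnc(/C(N)=N/NC(=S)N2CCCCC2)c1` with 15.3%

Both numbers come from the same test on cultured cancer cells, and the gap between them is within the usual scatter of such measurements, so compound 1 and compound 2 cannot be told apart on what has been measured. Compound 2 therefore stands on one of two numbers that, for practical purposes, read as one.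

Compound 3 `Cc1ccnc(/C(N)=N/NC(=S)N2CCCC2)c1` is the next compound to be measured. It differs from compound 2 in a single place: pyrrolidin-1-yl in place of piperidin-1-yl on a thiocarbonyl carbon. The same five-membered ring is already present in compound 1, whose value sits within the scatter of compound 2.

For the measured compounds named here, no measured pair shows the effect of this exact swap on the core of compound 2, so the expectation rests on compound 1 and compound 2 alone. For compound 3 the expected step is a number 3.7 percentage points higher from compound 2 to compound 3 (within the scatter), that is, nothing beyond the scatter. The estimated value for compound 3 in this assay is 19%, with a range from 8% to 31%.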

Compound 3, percent growth inhibition at one concentration: 25.9%
Compound 3: middle estimate off by 6.9 percentage points, on the low side; the measured number falls inside the stated range.
By their numbers in this assay, from the lowest: compounds 2, 1 and 3 (each within the scatter of the next, the first and the last beyond it).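

In this assay, the change to pyrrolidin-1-yl in place of piperidin-1-yl on a thiocarbonyl carbon gives a number 10.6 percentage points higher from compound 2 to compound 3 (beyond the scatter) on the core of compound 2, a modest step and the first one here to pass beyond the scatter. By contrast, methyl in place of hydrogen on an aromatic carbon gives a number 1.2 percentage points higher from compound 1 to compound 3 (within the scatter) and cannot be told from repeat-to-repeat variation in this single pair. No measurement shown offers an explanation for either step.

On these data alone, the ring step rests on one pair of compounds, so it remains open whether it would recur on the core of compound 1. Also open, as far as these compounds go, is how a morpholine ring or an open-chain dimethylamino group on the same thiocarbonyl carbon would read in this test.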